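Ester chain length and the cytotoxicity read-out

This account rests on a few compounds, and the source may have more. Where it says the series, first, only, none or still open, it means among the compounds named here.

Three esters of the shared core have been measured. Compound 1 `CCCOC(=O)CCC(=O)N1CCN(CCCOc2cc3c(Nc4ccc(F)c(Cl)c4)ncnc3cc2OC)CC1` gives 70.4% in a functional assay on A549 cells (Homo sapiens) for cytotoxicity, read by MTT assay, with a stated time of 24 h, tested at 60 uM; on this read-out higher numbers stand for a weaker effect at the one concentration tested and lower numbers for a stronger effect; compound 2 `CCCCCCOC(=O)CCC(=O)N1CCN(CCCOc2cc3c(Nc4ccc(F)c(Cl)c4)ncnc3cc2OC)CC1` gives 63.6%; compound 3 `CCCCCCCCCCCCCOC(=O)CCC(=O)N1CCN(CCCOc2cc3c(Nc4ccc(F)c(Cl)c4)ncnc3cc2OC)CC1` gives 20.6%, the lowest of the three. The step of a number 6.8 percentage points lower from compound 1 to compound 2 (within the scatter) stays within the scatter, whereas a number 49.8 percentage points lower from compound 1 to compound 3 (beyond the scatter) and a number 43 percentage points lower from compound 2 to compound 3 (beyond the scatter) are large. Compound 4 `CCCCCCCCCCCCCCCCCCCCOC(=O)CCC(=O)N1CCN(CCCOc2cc3c(Nc4ccc(F)c(Cl)c4)ncnc3cc2OC)CC1` extends the chain once more: heptyl in place of hydrogen on a saturated chain carbon, ten or more bonds along the chain from an oxygen next to a carbonyl group. The two large steps bear on this change; the propyl step does not, and nothing shows whether the trend holds past compound 3. With compound 3 at 20.6%, a further lowering of modest size is expected, estimated as a number 8.6 percentage points lower from compound 3 to compound 4 (within the scatter). Compound 4 is expected to give about 12%, within 2% to 32%.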

Compound 4, a percentage reported as activity, at one concentration (the size of the read-out at that concentration, not a potency): 86.9%
For compound 4 the middle estimate is 74.9 percentage points below the measured one; the whole stated range lies below it.
By their numbers in this assay, from the lowest: compound 3; then compounds 2 and 1 (each within the scatter of the next); then compound 4.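

In this assay heptyl in place of hydrogen on a saturated chain carbon gives a number 66.3 percentage points higher from compound 3 to compound 4 (beyond the scatter) and so reverses the lowering seen up to compound 3. Across these esters the number does not fall steadily with chain length, and compound 4 goes against any such trend. No measurement shown accounts for this reversal.

Where between the chains of compound 3 and compound 4 the turn lies remains open. So does the outcome for a chain ending in an amine or a carboxylic acid.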